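The source may report more compounds than this note shows. Statements on the series, on what has been measured and on what is new or still open speak of the compounds shown alone.

Compound 3 `Nc1ccccc1S(=O)(=O)N1CC(n2cc(F)c(=O)[nH]c2=O)OCc2ccccc21` gives the highest number of the three measured in a functional assay on MCF7 cells (Homo sapiens) for antiproliferative activity (a lower number here means a stronger inhibitor, a higher number a weaker inhibitor), namely 54800 nM. Compound 2 `Nc1ccc(S(=O)(=O)N2CC(n3cc(F)c(=O)[nH]c3=O)OCc3ccccc32)cc1` gives 14400 nM, and the change a 3.8-fold higher number from compound 2 to compound 3 (0.58 log units; beyond the scatter) shows the effect of moving the amino group. Compound 1 `O=[N+]([O-])c1ccc(S(=O)(=O)N2CC(n3cnc4ncnc(Cl)c43)OCc3ccccc32)cc1` gives 1220 nM, the lowest number shown. Compound 4 `Nc1ccccc1S(=O)(=O)N1CC(n2cnc3ncnc(Cl)c32)OCc2ccccc21` differs from compound 3 by a group of 10 heavy atoms (5 carbon, 4 nitrogen, 1 chlorine; one five-membered aromatic ring with 2 hetero atoms, one six-membered aromatic ring with 2 hetero atoms) in place of a group of 9 heavy atoms (4 carbon, 2 nitrogen, 2 oxygen, 1 fluorine; one six-membered aromatic ring with 2 hetero atoms), on a saturated ring carbon. Among the measured compounds shown here, no measured step isolates this exchange: compound 1 carries the entering group and compound 2 the leaving group, but they also differ at the sulfonyl aryl, so their values only hint that the entering group goes with a lower number. A clear drop is therefore expected, with the step of an 11-fold lower number from compound 3 to compound 4 (1.04 log units; beyond the scatter) anticipated. Compound 4 is estimated at 5000 nM, within 1500 nM to 20000 nM.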

Compound 4, half-maximal inhibitory concentration: 9140 nM
The estimate for compound 4 lay 1.8-fold (0.26 log units) below the measured number; the range from low to high includes it.
By their numbers in this assay, from the lowest: compound 1; then compounds 4 and 2 (each within the scatter of the next); then compound 3.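

In this assay the step of a 6.0-fold lower number from compound 3 to compound 4 (0.78 log units; beyond the scatter) isolates the exchange on the saturated ring carbon next to the ring oxygen, with the (2-aminophenyl)sulfonyl group held fixed. With that entering group held fixed in turn, the step of a 7.5-fold higher number from compound 1 to compound 4 (0.87 log units; beyond the scatter) shows that the sulfonyl aryl also changes the number in this second series. No measurement given explains either step. From the compounds shown here alone, whether the exchange gives a similar step with 4-aminophenyl on the sulfonyl sulfur stays open, as does the effect of an amine or a methoxy group in place of the chlorine.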